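The source may report more compounds than this note shows. Statements on the series, on what has been measured and on what is new or still open speak of the compounds shown alone.

Compound 1 `O=c1c2ccc(C(F)(F)F)nc2ncn1Cc1cc(-c2ccc(Cl)cc2)no1`: 870 nM
Compound 2 `CCc1nc2nc(C(F)(F)F)ccc2c(=O)n1Cc1cn(CCC(F)(F)C(F)(F)C(F)(F)C(F)(F)C(F)(F)C(F)(F)F)nn1`: 2830 nM
Compound 3 `O=C(Cn1cc(COc2nc(-c3ccccc3)nc3nc(C(F)(F)F)ccc23)nn1)Nc1ccccc1`: 650 nM

All three were tested in a functional assay on MDA-MB-231 cells (Homo sapiens) for antiproliferative activity, read by sulforhodamine B assay, with a stated time of 48 h; a lower number here means a stronger inhibitor of growth, a higher number a weaker inhibitor of growth. Compound 3 stands at the lowest number of the three. Compound 1 lies nearest, and the gap between compound 3 and compound 1 is within the scatter, so the two cannot be told apart. Compound 2 lies furthest, and its gap to compound 3 is beyond the scatter.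

Compound 4 `CCCCCCCCCCn1cc(COc2nc(-c3ccccc3)nc3nc(C(F)(F)F)ccc23)nn1` has not yet been measured in this assay. It differs from compound 3 in one place: nonyl in place of phenylcarbamoyl on a saturated chain carbon bound to an aromatic nitrogen. Among the compounds with values here, no measured pair isolates this kind of change, so the direction has to be guessed from what the set shows. Compound 2, which carries a long chain on the same kind of ring nitrogen but on a different core, gives 2830 nM, the highest number of the set. On that basis a modest step toward weaker inhibition is expected, a 1.8-fold higher number from compound 3 to compound 4 (0.27 log units; within the scatter), with wide uncertainty. Compound 4 is therefore estimated at 1200 nM, within a range of 400 nM to 3600 nM.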

Compound 4, concentration for 50% growth inhibition: 1050 nM
For compound 4 the middle estimate is 1.1-fold (0.06 log units) above the measured one; low and high end bracket the measured number.
By their numbers in this assay, from the lowest: compounds 3, 1 and 4 (each within the scatter of the next); then compound 2.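

In this assay, the exchange of phenylcarbamoyl for nonyl on a saturated chain carbon bound to an aromatic nitrogen gives a 1.6-fold higher number from compound 3 to compound 4 (0.21 log units; within the scatter), so the two compounds cannot be told apart. Within the data shown here, this pair is the first in which only this place varies, and it shows that the carbonyl, the amide hydrogen and the carbon-only aromatic ring can all give way to a plain carbon chain without a change beyond the scatter. No measurement shown here other than the growth-inhibition numbers bears on this result.

The compounds shown leave open whether a shorter chain or a longer chain at this place would give a similar number. They also leave open how a chain ending in an amine or a carboxylic acid would behave.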